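This account rests on a few compounds, and the source may have more. Where it says the series, first, only, none or still open, it means among the compounds named here.

Compound 1, `COc1ccc(N(Cc2ccccc2)NC(=O)NCCCN2CCN(c3ccccc3OC)CC2)cc1`: 1.7 nM
Compound 2, `COc1ccc(N(Cc2cccc(F)c2)NC(=O)NCCCN2CCN(c3ccccc3OC)CC2)cc1`: 6.2 nM
Compound 3, `COc1ccc(N(Cc2cccc(OC)c2)NC(=O)NCCCN2CCN(c3ccccc3OC)CC2)cc1`: 33 nM

In an assay on CHO cells for displacement of a labelled ligand from D(4) dopamine receptor (Homo sapiens), read by radioligand binding (on this read-out lower numbers stand for stronger inhibition and higher numbers for weaker inhibition), compound 3 gives the highest of the three numbers; the step of a 19-fold higher number from compound 1 to compound 3 (1.29 log units; beyond the scatter) is large, and a 5.3-fold higher number from compound 2 to compound 3 (0.73 log units; beyond the scatter) is modest. Compound 4, `C=C(C)CN(NC(=O)NCCCN1CCN(c2ccccc2OC)CC1)c1ccc(OC)cc1`, differs from compound 3 by 1-methylethenyl in place of 3-methoxyphenyl on a saturated chain carbon bound to a nitrogen on an aromatic ring. Among the compounds with values here, none of the measured steps removes the aromatic ring at this position: the steps of a 3.6-fold higher number from compound 1 to compound 2 (0.56 log units; beyond the scatter), a 19-fold higher number from compound 1 to compound 3 (1.29 log units; beyond the scatter) and a 5.3-fold higher number from compound 2 to compound 3 (0.73 log units; beyond the scatter) only exchange substituents on it. They show that this part of the molecule moves the read-out strongly, so a wide range is warranted. Compound 4 is expected to give 25 nM, between 4 nM and 160 nM, which means an estimated step of a 1.3-fold lower number from compound 3 to compound 4 (0.12 log units; within the scatter), within the scatter in either direction.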

Compound 4, inhibition constant: 64 nM
Compound 4: the middle estimate sits 2.6-fold (0.41 log units) below what was measured; the measured number falls inside the stated range.
By their numbers in this assay, from the lowest: compound 1; then compound 2; then compounds 3 and 4 (each within the scatter of the next).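

In this assay, a ring-free 2-methylprop-2-en-1-yl group matches the 3-methoxybenzyl group, with a 1.9-fold higher number from compound 3 to compound 4 (0.29 log units; within the scatter), so the aromatic ring is not required to reach the level of compound 3. The same change costs far more against the other two benzyl compounds, with a 10-fold higher number from compound 2 to compound 4 (1.01 log units; beyond the scatter) and a 38-fold higher number from compound 1 to compound 4 (1.58 log units; beyond the scatter), so the unsubstituted and 3-fluoro rings hold an advantage that the 3-methoxy ring does not. No available evidence explains these differences. As far as these compounds go, how a saturated 2-methylpropyl group, a longer chain or an amine at this place would read remains open.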